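Two Limits and a Reoriented Ester Analogue

The compounds below may be only part of what the source reports. "The series", "measured", "known", "first", "only" and "open" are said of these compounds alone.

Compound 1 `COc1cc(Cc2cnc(N)nc2N)cc(/C=C/C(=O)N2N=Cc3ccccc3C2c2ccc(CO)cc2)c1O` in an assay on isolated protein for inhibition of Dihydrofolate reductase (Homo sapiens) (on this read-out lower numbers stand for stronger inhibition and higher numbers for weaker inhibition), gives > 24000 nM, a limit of the assay.
Compound 2 `COc1cc(Cc2cnc(N)nc2N)cc(/C=C/C(=O)N2N=Cc3ccccc3C2c2ccccc2CN(C)C)c1OC` in this assay gives > 42000 nM, also a limit.

Compound 2 therefore stands at a limit with no number of its own, and compound 1 offers only a limit as well, so no order between the two can be drawn. Compound 3 `COC(=O)C(C)(C)C1c2ccccc2C=NN1C(=O)/C=C/c1cc(Cc2cnc(N)nc2N)cc(OC)c1OC` differs from compound 2 by 1-(methoxycarbonyl)-1-methylethyl in place of 2-((dimethylamino)methyl)phenyl on a saturated ring carbon. For the measured compounds named here, no measured step covers this change, so compound 3 is expected to remain weak, and the step of an at least 1.0-fold lower number from compound 2 to compound 3 (0.02 log units; that floor lies within the scatter) is expected to stay within the scatter. Compound 3 is estimated at 40000 nM, between 8000 nM and 150000 nM, most probably again only a limit.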

Compound 3, half-maximal inhibitory concentration: 813000 nM
Compound 3: the middle estimate sits 20-fold (1.31 log units) below what was measured; the measured number lies above the stated range.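

Compound 2 carries only a limit, so the step from compound 2 to compound 3 cannot be read. From the compounds shown here alone, it remains open whether 1-(methoxycarbonyl)-1-methylethyl in place of 2-((dimethylamino)methyl)phenyl raises or lowers the number in this assay.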